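This account rests on a few compounds, and the source may have more. Where it says the series, first, only, none or still open, it means among the compounds named here.

In a functional assay on HeLa cells (Homo sapiens) for antiproliferative activity, read by MTT assay, with a stated time of 48 h (a higher number here means a weaker inhibitor, a lower number a stronger inhibitor), compound 3 `CC[C@@H](C)[C@H](NC(=O)c1ccc(Oc2nc3ccccc3nc2NC(C)(C)C)cc1)C(=O)O` gives 13400 nM, the lowest number of the series, compared with compound 2 `CC[C@@H](C)[C@H](NC(=O)c1ccc(Oc2nc3ccccc3nc2NC(C)(C)C)cc1)C(=O)OC` at 31900 nM and compound 1 `COC(=O)[C@H](C)NC(=O)c1ccc(Oc2nc3ccccc3nc2NC(C)(C)C)cc1` at 55200 nM. Compound 4 `CC(C)C[C@H](NC(=O)c1ccc(Oc2nc3ccccc3nc2NC(C)(C)C)cc1)C(=O)O` differs from compound 3 by isobutyl in place of sec-butyl on a saturated chain carbon bound to an amide-type nitrogen and a carbonyl carbon. The closest guide is a 1.7-fold lower number from compound 1 to compound 2 (0.24 log units; within the scatter), a change at that same place, with sec-butyl in place of methyl. The modest 2.4-fold lower number from compound 2 to compound 3 (0.38 log units; beyond the scatter) concerns a different place, which compound 4 leaves as in compound 3. No step beyond the scatter is therefore expected in this assay. The expected step is a 1.1-fold higher number from compound 3 to compound 4 (0.05 log units; within the scatter). For compound 4, the estimate is 15000 nM, with an expected range of 7000 nM to 32000 nM.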

Compound 4, half-maximal inhibitory concentration: 39200 nM
Estimate against measurement, compound 4: 2.6-fold (0.42 log units) below; measured number outside the range, above it.
By their numbers in this assay, from the lowest: compound 3; then compounds 2, 4 and 1 (each within the scatter of the next).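

In this assay, the same four carbons arranged differently give a 2.9-fold higher number from compound 3 to compound 4 (0.47 log units; beyond the scatter), so this position responds to how the chain is branched, which the change from methyl to sec-butyl, within the scatter, did not reveal. Against the two methyl esters, which differ in more than one place, the result is a 1.2-fold higher number from compound 2 to compound 4 (0.09 log units; within the scatter) and a 1.4-fold lower number from compound 1 to compound 4 (0.15 log units; within the scatter), so a free carboxylic acid does not by itself keep the number low. No measurement here accounts for the effect of the branch. From the compounds shown here alone, whether a straight butyl chain or a benzyl group at this place would behave like sec-butyl or isobutyl remains open.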